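Swapping the aryl group on the amide of compound 1

The source may report more compounds than this note shows. Statements on the series, on what has been measured and on what is new or still open speak of the compounds shown alone.

Measured so far:
- compound 1, `O=C(c1ccc(OC(F)(F)F)cc1)N1CCC(N(C2CC2)S(=O)(=O)c2cccc(C(F)(F)F)c2)CC1`: 73%
- compound 2, `CS(=O)(=O)c1ccc(C(=O)N2CCC(N(C3CC3)S(=O)(=O)c3cccc(C(F)(F)F)c3)CC2)cc1`: "not determined" (no result reported)

Compound 1 was tested in an assay on cells for inhibition of Voltage-dependent L-type calcium channel subunit alpha-1C (Homo sapiens), read by FLIPR and calcium flux, tested at 1 uM (a lower number here means a weaker effect, a higher number a stronger effect of the compound at the concentration tested), and gave 73%. Within the data shown here, it is the only compound here with a number; compound 2 shares the same core but in this assay compound 2 gives "not determined" (no result reported), so nothing can be said about it. Compound 3, `CS(=O)(=O)c1ccccc1C(=O)N1CCC(N(C2CC2)S(=O)(=O)c2cccc(C(F)(F)F)c2)CC1`, has not been measured yet. The change from compound 1 to compound 3 is 2-(methylsulfonyl)phenyl in place of 4-(trifluoromethoxy)phenyl on a carbonyl carbon. Among the measured compounds shown here, no pair of measured compounds differs in one place, so there is no earlier step to lean on. Given that, the expectation for compound 3 rests only on the single reading of compound 1 and is therefore uncertain. The step from compound 1 to compound 3, expected as a number 23 percentage points lower from compound 1 to compound 3 (beyond the scatter), is estimated to be a moderate decrease, with a wide range. Compound 3 is expected to give 50%, between 20% and 80%.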

Compound 3, a percentage reported as inhibition, at one concentration (the size of the read-out at that concentration, not a potency): 19%
Beside the measured number, compound 3's estimate is 31 percentage points above it; measured number outside the range, below it.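

In this assay, putting 2-(methylsulfonyl)phenyl in place of 4-(trifluoromethoxy)phenyl on the carbonyl carbon gives a clear loss of effect (a number 54 percentage points lower from compound 1 to compound 3 (beyond the scatter)). Among these compounds, the rest of the molecule stays the same, so this is the first sign that the read-out at this single concentration depends strongly on the aryl group at this position. Nothing available explains why this swap has such a large effect.

With no result for compound 2, the compounds shown cannot separate the effect of the methylsulfonyl group itself from that of its place on the ring, or from the loss of the trifluoromethoxy group. From the compounds shown here alone, it also remains open how an unsubstituted phenyl, or a phenyl carrying an amine or a carboxylic acid, would behave on this carbonyl carbon.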